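Working notes: linker exchange on the aromatic ring of compound 1

The source may report more compounds than this note shows. Statements on the series, on what has been measured and on what is new or still open speak of the compounds shown alone.

Compound 1 `CN(C)C(=O)c1cc2cnc(Nc3ccc(S(=O)(=O)NCCCCN=C=S)cc3)nc2n1C1CCCC1` and compound 2 `CN(C)C(=O)c1cc2cnc(Nc3ccc(C(=O)NCCCCCCCN=C=S)cc3)nc2n1C1CCCC1` share the same core and differ only in the group attached to the six-membered aromatic ring. In a functional assay on NCI-H1299 cells (Homo sapiens) for inhibition, read by CCK-8 assay, with a stated time of 72 h, tested at 10 uM (on this read-out higher numbers stand for a stronger effect at the one concentration tested and lower numbers for a weaker effect), compound 1 gives 72.7%, while compound 2 gives 107%. Compound 1 therefore stands lowest of the two numbers recorded; its nearest neighbour, compound 2, lies higher by a margin beyond the usual scatter. Going by the values given here, no pair of measured compounds differing in a single place exists here, so no measured step is available to anchor a prediction.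

Compound 3 `CN(C)C(=O)c1cc2cnc(Nc3ccc(NC(=O)CCCN=C=S)cc3)nc2n1C1CCCC1` has not been measured. Relative to compound 1 the change is a group of 9 heavy atoms (5 carbon, 2 nitrogen, 1 oxygen, 1 sulfur; no ring) in place of a group of 11 heavy atoms (5 carbon, 2 nitrogen, 2 oxygen, 2 sulfur; no ring), on an aromatic carbon. Among the compounds with values here, the only guidance comes from compound 2, whose different group on the same ring gives 107% against compound 1 at 72.7%; on that basis a rise in this assay is expected, and the step of a number 12.3 percentage points higher from compound 1 to compound 3 (beyond the scatter) is the estimated size, with the direction held more firmly than the magnitude. For compound 3 the expected value in this assay is 85%, within a range from 55% to 108%.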

Compound 3, a percentage reported as inhibition, at one concentration (the size of the read-out at that concentration, not a potency): 78.8%
For compound 3 the middle estimate is 6.2 percentage points above the measured one, within the range that was stated.
By their numbers in this assay, from the lowest: compounds 1 and 3 (each within the scatter of the next); then compound 2.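

Going by these compounds alone, on an aromatic carbon of a six-membered aromatic ring of carbon only, para to a large group, placing a group of 9 heavy atoms where compound 1 carries a group of 11 heavy atoms gives in this assay the first measured single-place step, a number 6.1 percentage points higher from compound 1 to compound 3 (within the scatter) and so leaves compound 1 and compound 3 indistinguishable on this read-out. This position therefore accepts a change in the size and composition of the group with no step beyond the scatter at the one concentration tested, although a single step cannot establish a trend. No supporting measurement is available to explain this result.

Because every value comes from one concentration in one cell line, the compounds shown leave open whether compound 1 and compound 3 also match in potency across a concentration range. Also open, as far as these compounds go, is how much of the effect depends on the isothiocyanate at the end of the chain, which an amine or a carboxylic acid in its place would test, and whether a longer chain on the amide of compound 3 would shift the read-out beyond the scatter.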